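The compounds below may be only part of what the source reports. "The series", "measured", "known", "first", "only" and "open" are said of these compounds alone.

For the measured compounds named here, compound 3 `CCCCCCOc1ccc(-n2cnnc2CCCC)cc1` gives 13.6 mg/kg in a functional assay on the whole organism (strain C57B/6) with Mus musculus as the target, in the maximal electroshock model (on this read-out higher numbers stand for an effect only at larger amounts of compound and lower numbers for an effect already at smaller amounts), the highest of the three numbers measured so far. Its nearest neighbour is compound 1 `CCCCCCOc1ccc(-n2cnnc2)cc1`, which gives 9.8 mg/kg in this assay, and the step of a 1.4-fold higher number from compound 1 to compound 3 (0.14 log units; within the scatter) stays within the scatter. Compound 2 `CCCCCCOc1ccc(-n2cnnc2CCC)cc1` gives 5.7 mg/kg, and the step of a 2.4-fold higher number from compound 2 to compound 3 (0.38 log units; beyond the scatter) is the only one among the three that goes beyond the scatter.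

Compound 4 `CCCCCCCCCc1nncn1-c1ccc(OCCCCCC)cc1` differs from compound 3 by pentyl in place of hydrogen on a saturated chain carbon, four bonds along the chain from an aromatic carbon. Going by the values given here, two steps bear on this change. The step of a 1.7-fold lower number from compound 1 to compound 2 (0.24 log units; within the scatter) and the step of a 1.4-fold higher number from compound 1 to compound 3 (0.14 log units; within the scatter) both introduce a chain on the aromatic carbon and each stays within the scatter. The step of a 2.4-fold higher number from compound 2 to compound 3 (0.38 log units; beyond the scatter) is the one that lengthens an existing chain, and it raised the number modestly. Because of a 2.4-fold higher number from compound 2 to compound 3 (0.38 log units; beyond the scatter), a further and much longer extension is expected to raise the number again, by a modest to moderate step, a 1.8-fold higher number from compound 3 to compound 4 (0.26 log units; within the scatter). Compound 4 is therefore estimated at 25 mg/kg, with a range from 10 mg/kg to 65 mg/kg.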

Compound 4, dose for half-maximal effect: > 40 mg/kg
Compound 4: no number, only a limit; the forecaster's own chance of this, stated with the estimate: 15%; middle value at least 1.6-fold (0.20 log units) from the limit.
By their numbers in this assay, from the lowest: compounds 2, 1 and 3 (each within the scatter of the next, the first and the last beyond it). At a limit, above all of these: compound 4.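

In this assay, compound 4 gives no number, only a limit: the limit of > 40 mg/kg in this assay, at which 1 of the 4 values shown sits.

Lengthening the chain at this position by pentyl moves the read-out beyond the scatter, with an at least 2.9-fold higher number from compound 3 to compound 4 (0.46 log units; beyond the scatter), and the hexyl extension of the propyl chain gives an at least 7.0-fold higher number from compound 2 to compound 4 (0.84 log units; beyond the scatter). For the compounds shown here, the earlier compounds showed propyl and butyl in place of hydrogen on the aromatic carbon staying within the scatter, whereas nonyl there gives an at least 4.0-fold higher number from compound 1 to compound 4 (0.61 log units; beyond the scatter), so this long chain is the first such replacement of hydrogen to leave the scatter.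

On these data alone, the true size of these three steps stays open, since each has only a lower bound. Also open, as far as these compounds go, is how a pentyl or hexyl chain on this carbon would read out, and whether a butyl chain ending in an amine or a carboxylic acid would follow the butyl or the nonyl compound.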